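A few compounds are considered here, and "the series" means these few. Any claim that something is new, unique, unknown or untested is made for them only; others in the source may bear on it.

Measured so far:
compound 1, `Cc1ccc2c(c1)C(=O)/C(=C(\S)N(C)c1ccccc1)C(=O)N2C`, 20%
compound 2, `CN1C(=O)/C(=C(/S)N(C)c2ccccc2)C(=O)c2cc(Cl)ccc21`, 64%; 64% (2 entries)

Notes on the series. The shared core carries a methyl in compound 1 and a chloro in compound 2 on the six-membered aromatic ring of carbon only. Within the data shown here, in a functional assay on the whole organism for inhibition, with Mus musculus as the target, at a dose of 10 mg/kg by the oral route (a lower number here means less inhibition, a higher number more inhibition at the dose given (going by the name of the read-out)), compound 1 gives 20%, the only number recorded for it; in this assay compound 2 gives 64%; 64% (2 entries), in two entries. Compound 3, `CN1C(=O)/C(=C(/S)N(C)c2ccccc2)C(=O)c2cc(Br)ccc21`, is not yet measured in this assay. Its change from compound 1: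
bromo in place of methyl on an aromatic carbon
Among the measured compounds shown here, no step between measured compounds is recorded. The bromo that enters is expected to move the read-out up, well beyond the scatter, by about a number 38 percentage points higher from compound 1 to compound 3 (beyond the scatter), taking the chloro analogue compound 2 at 64%; 64% (2 entries) as the nearest guide. Compound 3 is therefore estimated at 58% in this assay, with a range from 35% to 80%.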

Compound 3, a percentage reported as inhibition, in the whole organism at one dose (the size of the read-out at that dose, not a potency): 56%
Beside the measured number, compound 3's estimate is 2 percentage points above it, and the stated range covers the measured number.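

In this assay, among these compounds, bromo in place of methyl on an aromatic carbon gives a number 36 percentage points higher from compound 1 to compound 3 (beyond the scatter), the first recorded step at this position, so the read-out depends strongly on the group on this carbon. Compound 2, the chloro analogue, reads 64%; 64% (2 entries) and compound 3 reads 56%, so the two halogen compounds can be set side by side. Nothing measured here accounts for the step.

Still open, going by these compounds, is how a methoxy, an amine or a carboxylic acid on this carbon would read. Also open, on these data alone, is whether the other positions of the shared core respond as strongly to change.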